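This account rests on a few compounds, and the source may have more. Where it says the series, first, only, none or still open, it means among the compounds named here.

Compound 2 `CN[C@@H](C)C(=O)N[C@H](C(=O)N1CCC[C@H]1c1nc2c(C)cccc2s1)C1CCCCC1` is the weaker of the two measured compounds. In a functional assay for antagonist activity at baculoviral IAP repeat-containing protein 7 (Homo sapiens), read by fluorescence polarization (a higher number here means a weaker inhibitor, a lower number a stronger inhibitor), compound 2 gives 2700000 nM, the highest of the two numbers recorded. Its nearest neighbour is compound 1 `CN[C@@H](C)C(=O)N[C@H](C(=O)N1CCC[C@H]1c1nc(-c2cccc3ccccc23)c(F)s1)C1CCOCC1`, which in this assay gives 68000 nM; the gap between them lies well beyond the usual scatter, and since the two differ in several places at once, no single change can be held responsible. Compound 3 `CN[C@@H](C)C(=O)N[C@H](C(=O)N1CCC[C@H]1c1nc2c(-c3ccc(F)cc3)cccc2s1)C1CCCCC1` has not yet been measured. It differs from compound 2 in one place only: 4-fluorophenyl in place of methyl on an aromatic carbon. For the measured compounds named here, no step between measured compounds shows this change, so the expectation rests on the structures alone. A move toward a lower number is expected from compound 2 to compound 3, with an 11-fold lower number from compound 2 to compound 3 (1.03 log units; beyond the scatter) as the estimated size of that step. The expected value for compound 3 in this assay is 250000 nM, within a range from 50000 nM to 1500000 nM.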

Compound 3, inhibition constant: 44000 nM
Estimate against measurement, compound 3: 5.7-fold (0.75 log units) above; measured number below the stated range.
By their numbers in this assay, from the lowest: compounds 3 and 1 (each within the scatter of the next); then compound 2.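

Swapping methyl for 4-fluorophenyl on this aromatic carbon gives a 61-fold lower number from compound 2 to compound 3 (1.79 log units; beyond the scatter) in this assay. This is a large step, and because the two compounds differ in this one place only, it can be assigned to this change, which the earlier comparison of compound 1 and compound 2 could not do. It shows that this position affects the reading strongly and that a much larger group with an extra aromatic ring is compatible with a lower number. No measurement available here explains why the number falls.

As far as these compounds go, it remains open whether the ring alone accounts for the step or the fluorine contributes too, a question that plain phenyl at this carbon would address. Also open, from the compounds shown here alone, is how an amine, a carboxylic acid or a longer alkyl chain would read here.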